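Spirocyclic amide gives way to an oxolanyl amide

A few compounds are considered here, and "the series" means these few. Any claim that something is new, unique, unknown or untested is made for them only; others in the source may bear on it.

Three compounds have so far been measured in an assay on HEK293 cells for positive allosteric modulation of metabotropic glutamate receptor 5 (Homo sapiens), read by FLIPR, with a stated time of 1 h; a lower number here means that less compound is needed, a higher number that more compound is needed for the effect:

Compound 1, `CN1CCc2nc(C#Cc3ccccc3)sc2C1`, which in this assay gives 34 nM.
Compound 2, `C(#Cc1nc2c(s1)CN(C1CCCCC1)CC2)c1ccccc1`, which in this assay reaches only a limit, > 10000 nM.
Compound 3, `O=C(C1CC12CCC2)N1CCc2nc(C#Cc3ccccc3)sc2C1`, which in this assay gives 3.9 nM.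

Compound 3 stands lowest of the two numbers available. Its nearest neighbour is compound 1, with an 8.7-fold lower number from compound 1 to compound 3 (0.94 log units; beyond the scatter). Compound 2 is a limit rather than a number, (the limit of > 10000 nM in this assay, at which 1 of the 3 values shown sits). The other two steps are large: an at least 290-fold higher number from compound 1 to compound 2 (2.46 log units; beyond the scatter), and an at least 2500-fold lower number from compound 2 to compound 3 (3.40 log units; beyond the scatter).

Compound 4, `O=C(C1CCCO1)N1CCc2nc(C#Cc3ccccc3)sc2C1`, differs from compound 3 in one place: a group of 5 heavy atoms (4 carbon, 1 oxygen; one five-membered non-aromatic ring with 1 hetero atom) in place of a group of 6 heavy atoms (6 carbon; one three-membered non-aromatic ring of carbon only, one four-membered non-aromatic ring of carbon only), on a carbonyl carbon. Among the measured compounds shown here, none of the measured steps bears directly on this change; all three alter the group on the amine nitrogen in the ring, and in each of them the carbonyl-bearing group either appears or is absent as a whole. They show that the group on that nitrogen decides much of the outcome, but not how an oxolanyl compares with the spirocyclic group on the carbonyl carbon. The expectation therefore rests on compound 3 alone and allows only a modest step in either direction: a 2.1-fold higher number from compound 3 to compound 4 (0.31 log units; beyond the scatter). Compound 4 is thus estimated at 8 nM, within a range of 2 nM to 40 nM.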

Compound 4, half-maximal effective concentration: 790 nM
Compound 4: middle estimate off by 99-fold (1.99 log units), on the low side, outside the stated range (above it).
By their numbers in this assay, from the lowest: compound 3; then compound 1; then compound 4. At a limit, above all of these: compound 2.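

In this assay, among the compounds shown here, the group on the carbonyl carbon whose other neighbour is the amide-type nitrogen in a ring proves decisive in its own right, a point the earlier steps could not show, as each of them changed the whole group on the amine nitrogen: oxolan-2-yl in place of the spirocyclic group gives a 200-fold higher number from compound 3 to compound 4 (2.31 log units; beyond the scatter). A carbonyl on that nitrogen is therefore not enough to improve on methyl, as the oxolanyl amide gives a 23-fold higher number from compound 1 to compound 4 (1.37 log units; beyond the scatter), whereas the spirocyclic amide gives an 8.7-fold lower number from compound 1 to compound 3 (0.94 log units; beyond the scatter). The cyclohexyl compound stands only at a limit, so its comparison with the oxolanyl amide has a size bounded on one side, and that comparison still favours the amide: an at least 12-fold lower number from compound 2 to compound 4 (1.10 log units; beyond the scatter).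

The compounds shown offer nothing that accounts for the size of this change. They leave open whether the step follows the ring oxygen or the change of ring, which a cyclopentyl group on the carbonyl carbon would help to separate.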